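Two Compounds, One Number, and a Fluoro Swap

The compounds below may be only part of what the source reports. "The series", "measured", "known", "first", "only" and "open" are said of these compounds alone.

Compound 1 (`CCC(O)Cc1cn(CC(=O)NCc2ccccc2)nn1`) gives 630 uM
Compound 2 (`O=C(Cn1cc(-c2cccc(C(F)(F)F)c2)nn1)NCc1ccccc1`) gives "non-toxic" (no number reported)

Both entries belong to an ADME assay on cells (spleen, Mus musculus, strain C57BL/6) for inhibition, read by flow cytometry and propidium iodide staining, with a stated time of 24 h, at 37 degrees C (on this read-out higher numbers stand for an effect only at larger amounts of compound and lower numbers for an effect already at smaller amounts), and are all that is known so far. Compound 2 has no single number there: its entry reads "non-toxic" (no number reported) and so it cannot be placed on the scale as an exact value.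

Compound 3 (`O=C(Cn1cc(-c2cccc(F)c2)nn1)NCc1ccccc1`) differs from compound 2 at one place only. That change fluoro in place of trifluoromethyl on an aromatic carbon puts fluoro in place of trifluoromethyl on an aromatic carbon, meta to a large group.

Among the compounds with values here, no measured step between two compounds is available, so nothing shows directly how large such a change can be. The expectation in this assay is therefore no step beyond the scatter, with no direction to favour. Within the data shown here, the only numerical anchor is compound 1 at 630 uM and the expected level stays near it. Compound 3 may also be expected to come back without a number, as compound 2 did. For compound 3 the estimated value is 500 uM with an expected range of 150 uM to 1500 uM in this estimate.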

Compound 3, concentration for half-maximal effect: "non-toxic" (no number reported)
For compound 3 the study gives words and no number, so the estimate cannot be set against anything.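

Compound 2 and compound 3 are both reported in this assay as "non-toxic" rather than with a number, so no step can be read between them. Going by these compounds, how far fluoro in place of trifluoromethyl shifts the value on this scale stays open. No other data here bear on this result.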